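From 4-nitrophenyl to 2-aminoethyl on an aromatic nitrogen

The source may report more compounds than this note shows. Statements on the series, on what has been measured and on what is new or still open speak of the compounds shown alone.

Three related compounds have been measured so far in a physicochemical assay for lipophilicity, at pH 7.4, tested at 10 mM (on this read-out higher numbers stand for higher lipophilicity and lower numbers for lower lipophilicity), and they spread widely. Compound 1 `Cc1cc(SSc2cc(C)nn2-c2ccccc2)n(-c2ccccc2)n1` reads 3.2 while compound 2 `Cc1cc(OCCOc2cc(C)nn2-c2ccccc2)n(-c2ccccc2)n1` reads -1.6 on this scale. Compound 3 `Cc1cc(COc2cc(C)nn2-c2ccc([N+](=O)[O-])cc2)n(-c2ccccc2)n1` reads 3.7 and holds the highest of the three numbers. It lies above compound 1 by more than the usual scatter of repeated measurements, and far above compound 2.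

The next compound keeps most of this structure. Among the compounds with values here, compound 4 `Cc1cc(OCc2cc(C)nn2-c2ccccc2)n(CCN)n1` carries 2-aminoethyl in place of 4-nitrophenyl on an aromatic nitrogen and has no measurement yet. Within the data shown here, no two measured compounds here differ in one place only, so nothing shows the size of such a step directly and the expectation rests on judgement. The swap takes away a whole aromatic ring, and compound 2 at -1.6 shows that low numbers do occur in this set. A large downward step is expected in this assay and the estimate is a number 3.10 log units lower from compound 3 to compound 4 (beyond the scatter) which would lie well beyond the scatter. For compound 4 the expected value is 0.6 with a likely range from -0.6 to 1.8 on this scale.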

Compound 4, distribution coefficient: 5
Compound 4: the middle estimate sits 4.40 log units below what was measured, and the stated range ends below it.
By their numbers in this assay, from the lowest: compound 2; then compound 1; then compound 3; then compound 4.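

In this assay, within the data shown here, the swap of 4-nitrophenyl for 2-aminoethyl on an aromatic nitrogen gives a number 1.30 log units higher from compound 3 to compound 4 (beyond the scatter), the only step at this position that can be read so far, and it points upward. A group of 9 heavy atoms with an aromatic ring leaves and a group of 3 heavy atoms with no ring and a hydrogen-bond donor enters, yet the number rises, so in this pair a smaller group with no ring does not go with a lower reading. No measurement at hand accounts for the direction or the size of this step.

The compounds shown leave open whether the rise belongs to the 2-aminoethyl group itself, or whether a plain ethyl group or a longer chain ending in an amine, such as 3-aminopropyl, would move the number the same way. They also leave open how a carboxylic acid at the end of the same short chain would read at this aromatic nitrogen, and whether the same swap would give a similar step on another core.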